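The source may report more compounds than this note shows. Statements on the series, on what has been measured and on what is new or still open speak of the compounds shown alone.

Compound 1 `Cc1nn2c(C(C)c3ccc(CC(C)C)cc3)nnc2s1`: 62%
Compound 2 `CCc1nn2c(C(C)c3ccc(CC(C)C)cc3)nnc2s1`: 49%

In a functional assay on the whole organism (strain Wistar albino) for inhibition, with Rattus norvegicus as the target, read by paw edema, with stated times of 30 min and 1.5 h, at a dose of 20 mg/kg by the oral route (on this read-out lower numbers stand for less inhibition and higher numbers for more inhibition at the one dose given (going by the name of the read-out)), compound 2 gives 49%, the lower of the two numbers measured; compound 1 gives 62%. Compound 3 `CCCc1nn2c(C(C)c3ccc(CC(C)C)cc3)nnc2s1` differs from compound 2 by methyl in place of hydrogen on a saturated chain carbon, two bonds along the chain from an aromatic carbon. Among the compounds with values here, only one measured step bears on this change: a number 13 percentage points lower from compound 1 to compound 2 (beyond the scatter), which extended the same chain by the same unit. Lengthening it once more is therefore expected to lower the read-out by a similar or somewhat smaller amount, giving a number 8 percentage points lower from compound 2 to compound 3 (within the scatter). Compound 3 is expected to give 41%, within a range from 28% to 54%.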

Compound 3, a percentage reported as inhibition, in the whole organism at one dose (the size of the read-out at that dose, not a potency): 24%
Estimate against measurement, compound 3: 17 percentage points above, and the stated range ends above it.
By their numbers in this assay, from the lowest: compound 3; then compound 2; then compound 1.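

Lengthening the chain from ethyl to propyl takes the fall further in this assay, with a number 25 percentage points lower from compound 2 to compound 3 (beyond the scatter) as the read-out, and this step is no smaller than a number 13 percentage points lower from compound 1 to compound 2 (beyond the scatter) for the preceding extension. Across these three compounds, the fall does not level off at this position, and the whole change from methyl to propyl gives a number 38 percentage points lower from compound 1 to compound 3 (beyond the scatter) at this dose. No evidence is available to explain this fall.

The compounds shown leave open whether a butyl chain would lower the read-out further. They also leave open how a branched isopropyl group or an amine at this position would read.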